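A few compounds are considered here, and "the series" means these few. Any claim that something is new, unique, unknown or untested is made for them only; others in the source may bear on it.

In an ADME assay on CCRF-CEM cells (Homo sapiens) for cytotoxicity (a higher number here means that more compound is tolerated, a lower number that less compound is tolerated), compound 1 (`CC(C)C[C@@H](CO)NC(=O)c1cnc2ccccc2c1Cl`) gives > 100 uM, which is a limit of the assay and not a number. Compound 2 (`O=C(NCCO)c1cnc2ccccc2c1Cl`) gives > 100 uM, also a limit. Among the measured compounds shown here, the only measured step is a step that the two limits leave unreadable from compound 1 to compound 2, and the evidence on it is the limit of > 100 uM in this assay, at which 2 of the 2 values shown sit. Compound 3 (`COC(=O)[C@H](CC(C)C)NC(=O)c1cnc2ccccc2c1Cl`) has methoxycarbonyl in place of hydroxymethyl on a saturated chain carbon bound to an amide-type nitrogen and a saturated chain carbon. That measured step gives no size to carry over, so no change beyond the scatter is expected in this assay. The expected step is a number no higher from compound 1 to compound 3 (the limit leaves the size open). For compound 3 the estimated value is 100 uM, with an expected range of 50 uM to 200 uM.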

Compound 3, half-maximal toxic concentration: 49.1 uM
The estimate for compound 3 lay 2.0-fold (0.31 log units) above the measured number, outside the stated range (below it).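

In this assay, methoxycarbonyl in place of hydroxymethyl at this saturated chain carbon gives an at least 2.0-fold lower number from compound 1 to compound 3 (0.30 log units; that floor lies within the scatter) and makes compound 3 the only compound shown with a number rather than a limit. The step therefore shows that this place can carry a change that lowers the tolerated concentration by at least the printed floor, though that floor does not clear the scatter. From the compounds shown here alone, the true size stays open, and only this floor can be read: the limit of > 100 uM in this assay, at which 2 of the 3 values shown sit.

The step to compound 2 cannot be read. Going by these compounds, whether a carboxylic acid or a primary amide at this place would also give a number, and whether methoxycarbonyl would do so on the chain of compound 2, remains open.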